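Anilide ring substitution in a hydroxamate-free HDAC4 series

This account rests on a few compounds, and the source may have more. Where it says the series, first, only, none or still open, it means among the compounds named here.

The shared core carries a glycolic anilide on one side and is kept unchanged across the series. Compound 1 `O=C(COc1ccc2cc(/C=C3/SC(=O)NC3=O)ccc2c1)Nc1ccc([N+](=O)[O-])cc1` gives 1700 nM in an assay on isolated protein for inhibition of histone deacetylase 4 (Homo sapiens), with a stated time of 1 h; on this read-out higher numbers stand for weaker inhibition and lower numbers for stronger inhibition. Compound 2 `O=C(COc1ccc2cc(/C=C3/SC(=O)NC3=O)ccc2c1)Nc1ccc(F)cc1` gives 1600 nM in this assay. Within the data shown here, the one measured step, a 1.1-fold lower number from compound 1 to compound 2 (0.03 log units; within the scatter), leaves the two compounds within the scatter of each other, so compound 2 cannot be called stronger than compound 1; it merely shows the lowest of the two numbers, with compound 1 nearest.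

Compound 3 `O=C(COc1ccc2cc(/C=C3/SC(=O)NC3=O)ccc2c1)Nc1c(F)cc(F)cc1Br` is not yet measured. Its change from compound 2 is 2-bromo-4,6-difluorophenyl in place of 4-fluorophenyl on an amide-type nitrogen. Among the measured compounds shown here, only the step from compound 1 to compound 2 bears on variation of this anilide ring, and that step was flat. For the measured compounds named here, no measured pair covers adding two further substituents to the ring or bromine in place of hydrogen, so the expectation rests on the flat step alone: a step in this assay of no size beyond the scatter is expected, in either direction, as no change at the digits printed from compound 2 to compound 3 (within the scatter). Compound 3 is therefore estimated at 1600 nM, with a range from 600 nM to 4500 nM.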

Compound 3, half-maximal inhibitory concentration: 1100 nM
Compound 3: middle estimate off by 1.5-fold (0.16 log units), on the high side, and the stated range covers the measured number.
By their numbers in this assay, from the lowest: compounds 3, 2 and 1 (each within the scatter of the next).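

The amide-type nitrogen of this series accepts a more heavily substituted ring than the earlier pair covered. In this assay, 2-bromo-4,6-difluorophenyl in place of 4-fluorophenyl is a 1.5-fold lower number from compound 2 to compound 3 (0.16 log units; within the scatter), and in place of 4-nitrophenyl it is a 1.5-fold lower number from compound 1 to compound 3 (0.19 log units; within the scatter), so the entering group, with 9 heavy atoms against 7 in 4-fluorophenyl, keeps compound 3 within the scatter of both other anilides, whereas the earlier step only exchanged one group for another on the ring. No independent data bear on why the read-out stays flat across these three anilides.

Bromine and the second fluorine enter together in this step, so what each contributes alone stays open, as does the reading for a 2-bromophenyl or 2,4-difluorophenyl group on the same nitrogen. Also open, on these data alone, is whether the flat picture survives on an anilide ring carrying an amine, a carboxylic acid or a methoxy group, or when the ring gives way to a longer alkyl chain.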